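Sulfonyl aryl variation in the squalene monooxygenase series

The compounds below may be only part of what the source reports. "The series", "measured", "known", "first", "only" and "open" are said of these compounds alone.

Among the measured compounds shown here, compound 2 `CCN(C/C=C/C#CC(C)(C)C)Cc1cccc(OCCN(C)S(=O)(=O)c2ccc(Br)s2)c1` stands highest of the two numbers measured so far in a functional assay on HepG2 cells for inhibition of squalene monooxygenase (Homo sapiens); a higher number here means a weaker inhibitor, a lower number a stronger inhibitor; in this assay compound 2 gives 390 nM. For the measured compounds named here, its only neighbour is compound 1 `CCN(C/C=C/C#CC(C)(C)C)Cc1cccc(OCCN(C)S(=O)(=O)Cc2cccs2)c1`, which in this assay gives 200 nM, and the step of a 2.0-fold higher number from compound 1 to compound 2 (0.29 log units; within the scatter) lies within the scatter. Compound 3 `CCN(C/C=C/C#CC(C)(C)C)Cc1cccc(OCCN(C)S(=O)(=O)c2cc(-c3ccsc3)cs2)c1` has not yet been measured. It differs from compound 2 in one place: 4-(thiophen-3-yl)thiophen-2-yl in place of 5-bromothiophen-2-yl on a sulfonyl sulfur. Going by the values given here, the single step on record touches the same sulfonyl sulfur, the change from compound 1 to compound 2, and that step stayed within the scatter. Nothing measured speaks to the 4-(thiophen-3-yl)thiophen-2-yl group itself, so no step beyond the scatter is foreseen in this assay for compound 3, and the range is kept wide to reflect how little the series says about this change. The expected step is a 1.0-fold higher number from compound 2 to compound 3 (0.01 log units; within the scatter). Compound 3 is therefore expected to give 400 nM in this assay, within 150 nM to 1100 nM.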

Compound 3, half-maximal inhibitory concentration: 90 nM
Compound 3: middle estimate off by 4.4-fold (0.65 log units), on the high side; the whole stated range lies above it.
By their numbers in this assay, from the lowest: compound 3; then compounds 1 and 2 (each within the scatter of the next).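

The sulfonyl sulfur, whose other neighbour is the sulfonamide nitrogen, now shows steps beyond the scatter in this assay, which the earlier pair did not: 4-(thiophen-3-yl)thiophen-2-yl in place of 5-bromothiophen-2-yl gives a 4.3-fold lower number from compound 2 to compound 3 (0.64 log units; beyond the scatter), and in place of (thiophen-2-yl)methyl it gives a 2.2-fold lower number from compound 1 to compound 3 (0.35 log units; beyond the scatter). The place therefore accepts a larger group, with 10 heavy atoms and 2 five-membered aromatic rings against 6 heavy atoms and one such ring for 5-bromothiophen-2-yl, and the number falls rather than rises against both earlier groups. No measurement at hand accounts for this fall, so it stands as an observation on these three compounds only.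

Still open is whether the second ring has to be a thiophene: the compounds shown do not tell how 4-phenylthiophen-2-yl or unsubstituted thiophen-2-yl on the sulfonyl sulfur would compare with compound 3. Also open, as far as these compounds go, is how far the place tolerates other additions, such as an amine or a carboxylic acid carried on the thiophen-3-yl ring.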